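This account rests on a few compounds, and the source may have more. Where it says the series, first, only, none or still open, it means among the compounds named here.

Compound 3 `Fc1ccc(C2(c3ccc(F)cc3)CNC(c3ccncc3)=N2)cc1` gives 160 nM in an assay on LM cells for displacement of a labelled ligand from Neuropeptide Y receptor type 5 (Homo sapiens) (a higher number here means a weaker inhibitor, a lower number a stronger inhibitor), the highest of the three numbers measured here, although the gap to compound 2 is small. Compound 2 `Fc1ccc(C2(c3ccc(F)cc3)CNC(c3ccsc3)=N2)cc1` gives 93 nM in this assay, and the difference is only a 1.7-fold higher number from compound 2 to compound 3 (0.24 log units; within the scatter). Compound 1 `O=[N+]([O-])c1cccc(C2=NC(c3ccc(F)cc3)(c3ccc(F)cc3)CN2)c1` gives 4.3 nM, far lower: the steps are a 37-fold higher number from compound 1 to compound 3 (1.57 log units; beyond the scatter) and a 22-fold higher number from compound 1 to compound 2 (1.34 log units; beyond the scatter). Compound 4 `N#Cc1cccc(C2=NC(c3ccc(F)cc3)(c3ccc(F)cc3)CN2)n1` carries 6-cyanopyridin-2-yl in place of pyridin-4-yl on a carbon with a double bond to nitrogen. Within the data shown here, all three measured steps exchange the group on this same carbon, and they show that such an exchange can move the number a great deal or hardly at all; no measured step exchanges one six-membered aromatic ring with one hetero atom for another, so the direction stays open. A moderate step downward is expected, a 2.7-fold lower number from compound 3 to compound 4 (0.43 log units; beyond the scatter). Compound 4 is estimated at 60 nM, within 10 nM to 400 nM.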

Compound 4, half-maximal inhibitory concentration: 39 nM
Compound 4: the middle estimate sits 1.5-fold (0.19 log units) above what was measured; measured number inside the range.
By their numbers in this assay, from the lowest: compound 1; then compound 4; then compounds 2 and 3 (each within the scatter of the next).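

Keeping a six-membered aromatic ring with one hetero atom on this carbon does not fix the number: 6-cyanopyridin-2-yl in place of pyridin-4-yl gives a 4.1-fold lower number from compound 3 to compound 4 (0.61 log units; beyond the scatter), and against thiophen-3-yl there is a 2.4-fold lower number from compound 2 to compound 4 (0.38 log units; beyond the scatter). The 3-nitrophenyl group still gives the lowest number, with a 9.1-fold higher number from compound 1 to compound 4 (0.96 log units; beyond the scatter). Nothing available explains these steps. Going by these compounds, whether the nitrile or the different ring attachment carries the drop stays open, since the two change together. On these data alone, how an amine or a carboxylic acid in place of the nitrile would fare also stays open.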